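A few compounds are considered here, and "the series" means these few. Any claim that something is new, unique, unknown or untested is made for them only; others in the source may bear on it.

Of the compounds shown here, three built on a shared core have been tested in a functional assay on BT-549 cells (Homo sapiens) for inhibition, read by sulforhodamine B assay, with a stated time of 48 h; a lower number here means a stronger inhibitor of growth, a higher number a weaker inhibitor of growth. Compound 1 `Nc1cc(N)c2nc(-c3ccccc3)c(Sc3ccc(F)cc3)nc2c1` gives 21900 nM. Compound 2 `COc1cc(CNc2nc3cc(N)cc(N)c3nc2-c2ccccc2)cc(OC)c1OC` gives 3800 nM, and compound 3 `CCOC(=O)[C@H](CCC(=O)O)NC(=O)c1ccc(Oc2nc3cc(N)cc(N)c3nc2-c2ccccc2)cc1` gives 33900 nM. Compound 1 stands second highest of the three numbers: its gap to compound 3 lies within the scatter, while compound 2 sits well below it, beyond the scatter. Compound 4 `Nc1cc(N)c2nc(-c3ccccc3)c(NCc3ccc(F)cc3)nc2c1` has not yet been measured. It differs from compound 1 in one place: (4-fluorobenzyl)amino in place of (4-fluorophenyl)sulfanyl on an aromatic carbon. Because compound 2, whose side group is likewise joined through nitrogen, gives 3800 nM, a moderate move toward a lower number is expected here, though three measured compounds leave this uncertain. The step of a 2.4-fold lower number from compound 1 to compound 4 (0.39 log units; beyond the scatter) is the expected outcome. For compound 4 the estimate is 9000 nM, within a range from 3000 nM to 27000 nM.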

Compound 4, concentration for 50% growth inhibition: 1700 nM
Estimate against measurement, compound 4: 5.3-fold (0.72 log units) above, and the stated range ends above it.
By their numbers in this assay, from the lowest: compound 4; then compound 2; then compounds 1 and 3 (each within the scatter of the next).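

Going by these compounds alone, at this aromatic carbon next to the ring nitrogen, placing (4-fluorobenzyl)amino where (4-fluorophenyl)sulfanyl stood gives a 13-fold lower number from compound 1 to compound 4 (1.11 log units; beyond the scatter) in this assay and is the first direct evidence that the side group here strongly affects the read-out. The change replaces the sulfur link with a nitrogen link, adds a carbon and brings in a hydrogen-bond donor, all at once. Nothing shown explains the size of this step.

Which of these differences carries the step remains open. Comparing (4-fluorobenzyl)sulfanyl and (4-fluorophenyl)amino at this carbon would begin to separate them.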